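This account rests on a few compounds, and the source may have more. Where it says the series, first, only, none or still open, it means among the compounds named here.

Of the compounds shown here, two of one series have been measured in an ADME assay on HepG2 cells (Homo sapiens) for cytotoxicity, read by luminescence, CellTiter-Glo and ATP content, with a stated time of 72 h; a higher number here means that more compound is needed for the effect, a lower number that less compound is needed. Compound 1, with the structure `COc1cccc(CNCCCNc2ccnc3cc(Oc4ccc(Cl)cc4)ccc23)c1O`, gives 5700 nM in this assay. Compound 2, with the structure `COc1cccc(CNCCCNc2ccnc3cc(-c4cc(C(F)(F)F)cc(C(F)(F)F)c4)ccc23)c1O`, gives 940 nM in this assay. On these two numbers, compound 1 stands highest, and the gap to compound 2 lies beyond the scatter of the assay.

The next compound, compound 3, has the structure `COc1ccc(-c2ccc3c(NCCCNCc4cccc(OC)c4O)ccnc3c2)cc1`. It differs from compound 1 in one place only: 4-methoxyphenyl in place of 4-chlorophenoxy on an aromatic carbon. Among the measured compounds shown here, no step between measured compounds covers this exact exchange, so any expectation rests on the two values known.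

Because compound 2 sits at 940 nM with a six-membered aromatic ring of carbon only attached directly at the same place, a modest step downward is expected, and the step from compound 1 to compound 3 is estimated at a 2.3-fold lower number from compound 1 to compound 3 (0.36 log units; beyond the scatter). For compound 3 the expected value in this assay is 2500 nM, within a range of 800 nM to 8000 nM.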

Compound 3, half-maximal effective concentration: 1600 nM
Compound 3: the middle estimate sits 1.6-fold (0.19 log units) above what was measured, within the range that was stated.
By their numbers in this assay, from the lowest: compounds 2 and 3 (each within the scatter of the next); then compound 1.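

In this assay, among the compounds shown here, putting 4-methoxyphenyl in place of 4-chlorophenoxy on an aromatic carbon gives a 3.6-fold lower number from compound 1 to compound 3 (0.55 log units; beyond the scatter), the first comparison in which only one place changes. Both groups hold the same number of heavy atoms and hydrogen-bond acceptors, and each has one six-membered aromatic ring of carbon only, yet the number still moves beyond the scatter, so this position responds even when those counts stay alike. No measurement at hand explains this step. The exchange alters both how the ring is attached to the core and which group that ring carries, and the compounds shown do not separate these two changes. Also open, as far as these compounds go, is how this position would respond to a ring carrying an amine or a carboxylic acid.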